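From Ethyl to tert-Butyl on Compound 1

The compounds below may be only part of what the source reports. "The series", "measured", "known", "first", "only" and "open" are said of these compounds alone.

Compound 1 `CC/C(=N\Nc1nc2ccccc2o1)c1ccccn1`: 409 nM
Compound 2 `C/C(=N\Nc1nc2ccccc2o1)c1ccc2ccccc2n1`: 7760 nM

Both values come from a functional assay on HT-29 cells (Homo sapiens) for antiproliferative activity, read by sulforhodamine B assay; on this read-out lower numbers stand for stronger inhibition and higher numbers for weaker inhibition. Compound 1 holds the lower of the two numbers, and the gap up to compound 2 lies beyond the usual scatter. These two compounds differ in more than one place, so their gap cannot be tied to any single change.

Compound 3 `CC(C)(C)/C(=N\Nc1nc2ccccc2o1)c1ccccn1` keeps the core of compound 1 and alters one group: tert-butyl in place of ethyl on a carbon with a double bond to nitrogen. Among the measured compounds shown here, no measured pair tests this kind of change, so any forecast remains loose. Starting from compound 1 at 409 nM, a moderate move toward a higher number, meaning weaker inhibition, is expected in this assay, although a result within the scatter would not be surprising. The expected change is a 2.0-fold higher number from compound 1 to compound 3 (0.29 log units; within the scatter). Compound 3 is estimated at 800 nM, with an expected range from 150 nM to 4000 nM.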

Compound 3, half-maximal inhibitory concentration: > 10000 nM
Compound 3 was reported as a limit; the forecaster's own chance of this, stated with the estimate: 5%; at least 12-fold (1.09 log units) between middle value and limit.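

Compound 3 gives the first measured test of the group on this carbon with a double bond to nitrogen. In this assay, the swap of ethyl for tert-butyl, with the rest of the structure unchanged, gives an at least 24-fold higher number from compound 1 to compound 3 (1.38 log units; beyond the scatter), so this position is far from indifferent to which carbon group it carries. The value of compound 3, > 10000 nM, is a limit and not a number, so the step has a lower bound but no exact size, and the compound sits at the end of the range this assay reports: the limit of > 10000 nM in this assay, at which 1 of the 3 values shown sits.

The compounds shown leave open how the value changes across groups of intermediate shape at this position, such as isopropyl, or with a longer chain such as n-butyl, so it remains unclear whether the loss builds gradually or appears abruptly. They also leave open whether a group carrying an amine or a hydroxyl at this carbon could match or improve on compound 1 at 409 nM.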